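Swapping the acid-bearing aryl tail on a glutamate receptor modulator

The source may report more compounds than this note shows. Statements on the series, on what has been measured and on what is new or still open speak of the compounds shown alone.

Compound 1: `Cc1c(OCCCCOCOc2ccc(C(=O)O)cc2)ccc(C(=O)CC2CCCC2)c1O`, 95.4%
Compound 2: `COC(=O)c1ccc(OCCCCOc2ccc(C(=O)CC(C)C)c(C)c2C)cc1`, 15.9%

Of the compounds shown here, two have been measured in an assay on HEK293 cells for positive allosteric modulation of metabotropic glutamate receptor 2 (Rattus norvegicus), read by thallium flux, with a stated time of 2.5 min; a higher number here means a larger maximal response, a lower number a smaller maximal response. Compound 1 reaches 95.4%, while compound 2 reaches only 15.9%. Of these two numbers, compound 1 stands highest, and its gap to compound 2 lies beyond the usual scatter of the measurement. The two compounds differ in several places at once, so no single change can be tied to that gap.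

Compound 3 is `Cc1c(OCCCCOc2ccc(F)c(C(=O)O)c2)ccc(C(=O)CC2CCCC2)c1O` and has not yet been measured. It is made from compound 1 by one change: 3-carboxy-4-fluorophenyl in place of (4-carboxyphenoxy)methyl on an oxygen on a saturated carbon. The acid group remains, but it now sits on a shorter, fluorine-bearing aryl group attached directly to the chain oxygen.

Going by the values given here, with no step between measured compounds that isolates this change, the expectation rests on compound 1 alone, whose 95.4% sets the starting point. A moderate decrease is expected, a number 25.4 percentage points lower from compound 1 to compound 3 (beyond the scatter), since the tail is rebuilt substantially. Compound 3 is therefore estimated to reach 70%, within 35% to 100%.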

Compound 3, largest response reached (reported as percent of maximum), in percent of the reference or control that the assay uses: 81%
Compound 3: the middle estimate sits 11 percentage points below what was measured; measured number inside the range.
By their numbers in this assay, from the lowest: compound 2; then compound 3; then compound 1.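

On an oxygen on a saturated carbon, 3-carboxy-4-fluorophenyl can take the place of (4-carboxyphenoxy)methyl at a modest cost in this assay: a number 14.4 percentage points lower from compound 1 to compound 3 (beyond the scatter). A large maximal response therefore does not depend on the exact (4-carboxyphenoxy)methyl tail, since a different aryl group carrying a carboxylic acid also gives one on the core of compound 1. No measurement shown here accounts for the size of this step.

This single swap changes the tail's length, the fluorine and the placement of the acid together, so the effect of each cannot be separated. Still open, on these data alone, are how a plain 3-carboxyphenyl group without the fluorine would compare, and whether a tetrazole could stand in for the carboxylic acid.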